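Adding a Third Methoxy Group to Compound 2

The compounds below may be only part of what the source reports. "The series", "measured", "known", "first", "only" and "open" are said of these compounds alone.

Compound 1 `COc1cc(-c2nnc(SCC(=O)Nc3ccc(/C(C)=N/O)cc3)n2-c2ccccc2)cc(OC)c1OC`, compound 2 `CCn1c(SCC(=O)Nc2ccc(/C(C)=N/O)cc2)nnc1-c1ccc(OC)c(OC)c1` and compound 3 `CCn1c(SCC(=O)Nc2ccc(/C(C)=N/O)cc2)nnc1-c1ccc(OC)cc1` share a core that carries an oxime-bearing anilide through a thioether link, and differ at the substituent on the triazole nitrogen and in the number of methoxy groups on the aromatic ring. In a functional assay on the whole organism (strain albino) for inhibition, with Rattus norvegicus as the target, read by paw edema, with stated times of 30 min and 4 h, at a dose of 0.28 mmol/kg by the oral route (a higher number here means more inhibition at the dose given (going by the name of the read-out), a lower number less inhibition), compound 1 gives 75%. Compound 2 gives 75% and compound 3 gives 73%. Compound 2 thus stands level with compound 1, the two highest of the three numbers, while all three lie within the scatter of one another. Going by the values given here, the only single-point step among them, a number 2 percentage points lower from compound 2 to compound 3 (within the scatter), came with hydrogen in place of methoxy on an aromatic carbon and left the read-out unchanged beyond the scatter.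

Compound 4 `CCn1c(SCC(=O)Nc2ccc(/C(C)=N/O)cc2)nnc1-c1cc(OC)c(OC)c(OC)c1` differs from compound 2 by methoxy in place of hydrogen on an aromatic carbon. The step from compound 2 to compound 3 bears on this change directly, since it also alters the methoxy count, and it was small. Compound 1, which carries three methoxy groups, shows the same value as compound 2. Compound 4 is therefore expected to stay within the scatter, a step of no change at the digits printed from compound 2 to compound 4 (within the scatter). The inhibition of compound 4 is estimated at 75%, between 63% and 85%.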

Compound 4, a percentage reported as inhibition, in the whole organism at one dose (the size of the read-out at that dose, not a potency): 70%
Beside the measured number, compound 4's estimate is 5 percentage points above it; the measured number falls inside the stated range.
By their numbers in this assay, from the lowest: compounds 4, 3, 1 and 2 (each within the scatter of the next).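

In this assay the third methoxy group, placed on an aromatic carbon ortho to a methoxy group and meta to a large group, gives a number 5 percentage points lower from compound 2 to compound 4 (within the scatter) and so adds no step beyond the scatter at this position. Together with a number 2 percentage points lower from compound 2 to compound 3 (within the scatter) on the removal side, the methoxy count on this ring has now been read in both directions from compound 2, and neither step leaves the scatter. With three methoxy groups held fixed, the earlier compounds offered no direct reading of the group on the aromatic nitrogen, whereas a number 5 percentage points lower from compound 1 to compound 4 (within the scatter) now gives one for ethyl in place of phenyl, and it also stays within the scatter; nothing available here bears on what lies behind these numbers.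

The compounds shown leave open whether this position would respond to a group other than methoxy, such as a hydroxy group, a chlorine atom or a longer ether chain like butoxy. Going by these compounds alone, they also leave open whether a propyl chain or a benzyl group on the aromatic nitrogen would move the read-out beyond the scatter, since every step so far remains within it.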